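Nitro in Place of Trifluoromethyl: An Expected Value

A few compounds are considered here, and "the series" means these few. Any claim that something is new, unique, unknown or untested is made for them only; others in the source may bear on it.

Measured compounds:
- compound 1, `COc1ccc(C)cc1-c1c(C)nn(-c2nc(-c3ccc(Cl)c(Cl)c3)c(SC(C)C)s2)c1C(=O)O`, gives 9500 nM
- compound 2, `Cc1nn(-c2nc(-c3ccc(Cl)c(Cl)c3)c(SC(C)C)s2)c(C(=O)O)c1-c1cncnc1`, gives 22000 nM
- compound 3, `Cc1nn(-c2nc(-c3ccc(Cl)c(Cl)c3)c(SC(C)C)s2)c(C(=O)O)c1-c1ccccc1C(F)(F)F`, gives 5200 nM

The three share one core and differ only in the group attached to a single aromatic carbon. In a functional assay on BJAB cells (Homo sapiens) for antiproliferative activity, with a stated time of 4 days (on this read-out higher numbers stand for an effect only at larger amounts of compound and lower numbers for an effect already at smaller amounts), compound 3 shows the lowest number of the three; compound 1 sits closest, a 1.8-fold lower number from compound 1 to compound 3 (0.26 log units; within the scatter), and compound 2 furthest, a 4.2-fold lower number from compound 2 to compound 3 (0.63 log units; beyond the scatter). The step of a 2.3-fold higher number from compound 1 to compound 2 (0.36 log units; beyond the scatter) shows the same position moving the number the other way.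

Compound 4, `Cc1nn(-c2nc(-c3ccc(Cl)c(Cl)c3)c(SC(C)C)s2)c(C(=O)O)c1-c1ccccc1[N+](=O)[O-]`, keeps all of compound 3 except one change: nitro in place of trifluoromethyl on an aromatic carbon. Among the measured compounds shown here, no measured pair sets nitro against trifluoromethyl, so the only guide is how far this position has moved so far, from within the scatter up to a modest step. The step of a 1.3-fold higher number from compound 3 to compound 4 (0.10 log units; within the scatter) is therefore expected to stay within the scatter, with a slight drift toward a higher number possible. The estimate for compound 4 in this assay is 6500 nM, within 2500 nM to 16000 nM.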

Compound 4, half-maximal effective concentration: 4700 nM
For compound 4 the middle estimate is 1.4-fold (0.14 log units) above the measured one; low and high end bracket the measured number.
By their numbers in this assay, from the lowest: compounds 4, 3 and 1 (each within the scatter of the next, the first and the last beyond it); then compound 2.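

Within this assay the step of a 1.1-fold lower number from compound 3 to compound 4 (0.04 log units; within the scatter) is the first at this position that keeps the aromatic ring and changes only the group on it. Nitro, which brings hydrogen-bond acceptors that trifluoromethyl lacks, can therefore take the place of trifluoromethyl here without a change that this read-out can separate from scatter. The 2-nitrophenyl group also stands clear of the other two groups at this position, with a 4.7-fold lower number from compound 2 to compound 4 (0.67 log units; beyond the scatter) against pyrimidin-5-yl and a 2.0-fold lower number from compound 1 to compound 4 (0.31 log units; beyond the scatter) against 2-methoxy-5-methylphenyl, the latter a small step.

Nothing available explains why nitro and trifluoromethyl read alike. From the compounds shown here alone, whether an amine, a carboxylic acid or a plain methyl on this same ring would also leave the number in place stays open, as does what a bare hydrogen there would do.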